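The compounds below may be only part of what the source reports. "The series", "measured", "known", "first", "only" and "open" are said of these compounds alone.

Compound 1 `CCCCn1nc2oc(=O)cc(C)c2c1C`: > 100 mg/kg
Compound 2 `CCCn1nc2oc(=O)cc(C)c2c1C`: 72.6 mg/kg
Compound 3 `CCCCn1nc(C)c2c(C)cc(=O)oc21`: > 100 mg/kg

In a functional assay on the whole organism with Mus musculus as the target, in the writhing test (on this read-out lower numbers stand for an effect already at smaller amounts and higher numbers for an effect only at larger amounts of compound), compound 3 gives > 100 mg/kg and this is a limit of the assay rather than a number. It is not alone there: the limit of > 100 mg/kg in this assay, at which 2 of the 3 values shown sit. Compound 4 `CCCCCn1nc(C)c2c(C)cc(=O)oc21` differs from compound 3 by methyl in place of hydrogen on a saturated chain carbon, four bonds along the chain from an aromatic nitrogen. Among the compounds with values here, the one measured step that bears on such a change is an at least 1.3-fold lower number from compound 1 to compound 2 (0.13 log units; that floor lies within the scatter) and it runs the opposite way, hydrogen in place of methyl, staying within the scatter. Lengthening the chain in compound 4 is therefore expected to give no step beyond the scatter in this assay and the expected step is a step that the limit leaves unreadable from compound 3 to compound 4. Compound 4 is estimated at 150 mg/kg with a range from 70 mg/kg to 320 mg/kg and may again reach only the limit.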

Compound 4, dose for half-maximal effect: > 100 mg/kg
Compound 4: no number, only a limit (the forecaster's own chance of this, stated with the estimate: 70%); the middle value lies beyond the limit too.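

No step can be read from compound 3 to compound 4, because both stand only at a limit of the assay and not at a number: the limit of > 100 mg/kg in this assay, at which 3 of the 4 values shown sit.

Left open is how far past that limit compound 3 and compound 4 lie, and so whether the longer chain of compound 4 changes the effect at all.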